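A few compounds are considered here, and "the series" means these few. Any claim that something is new, unique, unknown or untested is made for them only; others in the source may bear on it.

Compound 1 `COc1cc(/C=C/C(=O)OCCc2cccc(F)c2)cc(OC)c1O` and compound 2 `COc1ccccc1CCOC(=O)/C=C/c1cc(OC)c(O)c(OC)c1` share one core and differ only in the aryl group on a saturated chain carbon, two bonds along the chain from an oxygen next to a carbonyl group. In an assay on PMNL cells for inhibition of Polyunsaturated fatty acid 5-lipoxygenase (Homo sapiens), read by HPLC, with stated times of 5 min and 15 min (a lower number here means a stronger inhibitor, a higher number a weaker inhibitor), compound 1 gives 230 nM and compound 2 gives 250 nM, the higher of the two numbers but within the scatter of compound 1, as the step of a 1.1-fold higher number from compound 1 to compound 2 (0.04 log units; within the scatter) shows. Compound 3 `COc1cc(/C=C/C(=O)OCCCc2ccccc2)cc(OC)c1O` differs from compound 2 by benzyl in place of 2-methoxyphenyl on a saturated chain carbon, two bonds along the chain from an oxygen next to a carbonyl group. Within the data shown here, the only step bearing on this change, a 1.1-fold higher number from compound 1 to compound 2 (0.04 log units; within the scatter), stayed within the scatter, so no shift beyond the scatter is expected in this assay, an estimated 1.0-fold lower number from compound 2 to compound 3 (0.02 log units; within the scatter). Compound 3 is therefore estimated at 240 nM (range 120 nM to 500 nM).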

Compound 3, half-maximal inhibitory concentration: 340 nM
Estimate against measurement, compound 3: 1.4-fold (0.15 log units) below; measured number inside the range.
By their numbers in this assay, from the lowest: compounds 1, 2 and 3 (each within the scatter of the next).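

The position accepts benzyl as well as the two substituted phenyl groups: in this assay, the change gives a 1.4-fold higher number from compound 2 to compound 3 (0.13 log units; within the scatter), and the comparison with 3-fluorophenyl gives a 1.5-fold higher number from compound 1 to compound 3 (0.17 log units; within the scatter). Replacing 2-methoxyphenyl with benzyl removes the one hydrogen-bond acceptor of the leaving group, yet the step stays within the scatter. No measurement of any property bears on this result.

As far as these compounds go, whether an amine, a carboxylic acid or a longer chain at this position would give a step beyond the scatter remains open.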